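A few compounds are considered here, and "the series" means these few. Any claim that something is new, unique, unknown or untested is made for them only; others in the source may bear on it.

Measured compounds:
compound 1 `CCOC(=O)C1=C(Nc2ccccc2)S/C(=C\c2ccc(O)c(O)c2)C1=O` gives 6100 nM in a functional assay on JAR cells (Homo sapiens) for inhibition, read by MTT assay, with a stated time of 72 h; a higher number here means a weaker inhibitor, a lower number a stronger inhibitor
compound 2 `CCOC(=O)C1=C(Nc2ccccc2)S/C(=C\c2cc3cccnc3[nH]2)C1=O` gives 14400 nM in this assay

Among these two numbers, compound 2 stands highest in this assay; its nearest neighbour is compound 1, and the step of a 2.4-fold higher number from compound 1 to compound 2 (0.37 log units; beyond the scatter) is modest but beyond the scatter. Compound 3 `CCOC(=O)C1=C(Nc2ccccc2)S/C(=C\c2cc3ncccc3[nH]2)C1=O` is built from the same atoms as compound 2, joined differently: a group of 9 heavy atoms (7 carbon, 2 nitrogen; one five-membered aromatic ring with 1 hetero atom, one six-membered aromatic ring with 1 hetero atom) in place of a group of 9 heavy atoms (7 carbon, 2 nitrogen; one five-membered aromatic ring with 1 hetero atom, one six-membered aromatic ring with 1 hetero atom), on a double-bonded chain carbon bound to a double-bonded ring carbon. Within the data shown here, no measured step covers a change of this kind. Among the measured compounds shown here, the only step recorded, a 2.4-fold higher number from compound 1 to compound 2 (0.37 log units; beyond the scatter), concerns a different exchange, in which the whole catechol-bearing group left and the bicyclic group of compound 2 entered; it tells how much that larger swap cost, but nothing about rearranging the bicyclic group itself. For the measured compounds named here, with no step bearing on it, compound 3 is expected to sit close to compound 2 in this assay, with the step of a 1.0-fold lower number from compound 2 to compound 3 (0.01 log units; within the scatter) expected to lie within the scatter in either direction. Compound 3 is therefore estimated at 14000 nM in this assay, with a range from 5000 nM to 40000 nM.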

Compound 3, half-maximal inhibitory concentration: 9600 nM
Beside the measured number, compound 3's estimate is 1.5-fold (0.16 log units) above it; the measured number falls inside the stated range.
By their numbers in this assay, from the lowest: compounds 1, 3 and 2 (each within the scatter of the next, the first and the last beyond it).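

In this assay, rejoining the same atoms within the bicyclic group on the double-bonded chain carbon bound to a double-bonded ring carbon gave a step within the scatter (a 1.5-fold lower number from compound 2 to compound 3 (0.18 log units; within the scatter)), so this rearrangement does not separate the two isomers. Among these compounds, it also changes how the exchange from the group of compound 1 reads: that exchange lay beyond the scatter with the bicyclic group of compound 2 (a 2.4-fold higher number from compound 1 to compound 2 (0.37 log units; beyond the scatter)), but not with the one of compound 3 (a 1.6-fold higher number from compound 1 to compound 3 (0.20 log units; within the scatter)), so the cost seen earlier does not hold for both arrangements of these atoms. No measurement at hand offers an explanation for these numbers.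

Still open, going by these compounds, is whether a single pyridine ring or an unsubstituted phenyl ring on that same chain carbon would give a number distinct from those of the bicyclic groups. On these data alone, all three compounds also keep the ethyl ester on the shared core, so what a carboxylic acid or an amide there would do in this assay remains open as well.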